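The source may report more compounds than this note shows. Statements on the series, on what has been measured and on what is new or still open speak of the compounds shown alone.

The compounds measured so far:
Compound 1, `CC(C)(N)C(=O)N[C@H](COCc1cccc(Cl)c1)c1nnnn1CCOC(=O)NCCCCO`: 1.6 nM
Compound 2, `CC(C)(N)C(=O)N[C@H](COCc1cc(Cl)cc(Cl)c1)c1nnnn1CCOC(=O)NCCCCO`: 6.75 nM
Compound 3, `Cc1ccccc1COC[C@@H](NC(=O)C(C)(C)N)c1nnnn1CCOC(=O)NCCCCO`: 0.51 nM

All three were tested in a functional assay on cells for inhibition of growth hormone secretagogue receptor type 1 (Homo sapiens), read by FLIPR and calcium flux; on this read-out lower numbers stand for an effect already at smaller amounts and higher numbers for an effect only at larger amounts of compound. Compound 3 stands lowest of the three; both steps that lead to it, a 3.1-fold lower number from compound 1 to compound 3 (0.50 log units; beyond the scatter) and a 13-fold lower number from compound 2 to compound 3 (1.12 log units; beyond the scatter), are beyond the scatter, so it is the most potent compound measured here.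

Compound 4, `CC(C)(N)C(=O)N[C@H](COCc1ccccc1-c1cccnc1)c1nnnn1CCOC(=O)NCCCCO`, is compound 3 with one change: pyridin-3-yl in place of methyl on an aromatic carbon. The new group sits on an aromatic carbon of a six-membered aromatic ring of carbon only, ortho to a large group. Among the measured compounds shown here, no measured step adds a whole ring at this position. The closest guides are a 4.2-fold higher number from compound 1 to compound 2 (0.63 log units; beyond the scatter), where a single atom added to the ring raised the number, and the two aryl swaps above, which shifted the number modestly to largely in either direction. Because a 4.2-fold higher number from compound 1 to compound 2 (0.63 log units; beyond the scatter) shows that enlarging the ring raised the number, a modest rise is expected for compound 4, a 2.9-fold higher number from compound 3 to compound 4 (0.47 log units; beyond the scatter). Compound 4 is therefore estimated at 1.5 nM, within a range of 0.4 nM to 6 nM.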

Compound 4, half-maximal effective concentration: 1.18 nM
The estimate for compound 4 lay 1.3-fold (0.10 log units) above the measured number, within the range that was stated.
By their numbers in this assay, from the lowest: compound 3; then compounds 4 and 1 (each within the scatter of the next); then compound 2.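

Compound 3's aromatic ring accepts a whole pyridin-3-yl ring in place of methyl, with six heavy atoms entering where one leaves, and the step is only a 2.3-fold higher number from compound 3 to compound 4 (0.36 log units; beyond the scatter) in size. Against the other aryl groups, 2-(pyridin-3-yl)phenyl gives a 5.7-fold lower number from compound 2 to compound 4 (0.76 log units; beyond the scatter) when it replaces 3,5-dichlorophenyl, whereas replacing 3-chlorophenyl gives a 1.4-fold lower number from compound 1 to compound 4 (0.13 log units; within the scatter) and so no real difference. No measurement available here explains why a group this large changes the number so little.

Going by these compounds, what a plain phenyl, a pyridin-2-yl or an amine would do at this place remains open. So does whether the nitrogen of the pyridin-3-yl group matters at all, or whether a carbon ring of the same size would give the same number.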